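The source may report more compounds than this note shows. Statements on the series, on what has been measured and on what is new or still open speak of the compounds shown alone.

Measured compounds:
Compound 1 `CCOC(=O)c1cnn(-c2nc(-c3ccccc3Cl)c(C#N)c(=O)n2C)c1N` gives 98 ug/mL in a functional assay, with a stated time of 10 min; on this read-out lower numbers stand for stronger inhibition and higher numbers for weaker inhibition.
Compound 2 `CSc1nc(-c2ccc(N(C)C)cc2)c(C#N)c(=O)n1C` gives 84 ug/mL in this assay.
Compound 3 `COc1ccc(-c2nc(NN)n(C)c(=O)c2C#N)cc1` gives 32 ug/mL in this assay.

Among these three, compound 1 carries the highest number. Compound 2 sits closest to compound 1, within the scatter of repeat measurements, so the two cannot be ordered. Compound 3 is furthest from compound 1, with a gap beyond the scatter.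

Compound 4 `CCOC(=O)c1cnn(-c2nc(-c3ccc(N(C)C)cc3)c(C#N)c(=O)n2C)c1N` is the untested compound. It differs from compound 1 in one place: 4-(dimethylamino)phenyl in place of 2-chlorophenyl on an aromatic carbon

Among the measured compounds shown here, no step between measured compounds that differ in one place is known. Compound 2, which also carries the 4-(dimethylamino)phenyl group, gives 84 ug/mL, close to compound 1, so little movement is expected. Compound 4 is expected at 85 ug/mL, within 40 ug/mL to 180 ug/mL, a step of a 1.2-fold lower number from compound 1 to compound 4 (0.06 log units; within the scatter) of no size beyond the scatter.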

Compound 4, half-maximal inhibitory concentration: 119 ug/mL
Compound 4: middle estimate off by 1.4-fold (0.15 log units), on the low side; measured number inside the range.
By their numbers in this assay, from the lowest: compound 3; then compounds 2, 1 and 4 (each within the scatter of the next).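

In this assay, putting 4-(dimethylamino)phenyl in place of 2-chlorophenyl on this aromatic carbon gives a 1.2-fold higher number from compound 1 to compound 4 (0.08 log units; within the scatter), so the two compounds cannot be told apart. Among the compounds shown here, this is the first direct comparison at this position, and it shows two differently substituted phenyl groups giving matching read-outs on the shared core. No measurement here offers an explanation for this match. Going by these compounds, whether the position accepts groups other than a substituted phenyl remains open. A simple amine, a carboxylic acid or a short alkyl chain at this carbon might give a clearly different number.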